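Replacing the 4-chlorobenzyl group of compound 2

The source may report more compounds than this note shows. Statements on the series, on what has been measured and on what is new or still open speak of the compounds shown alone.

In a functional assay on HCT-116 cells (Homo sapiens) for inhibition, read by CCK-8 assay, with a stated time of 48 h (a lower number here means a stronger inhibitor, a higher number a weaker inhibitor), compound 1 `COc1ccc(CN(C(=O)CSC(=S)N2CCN(C(=O)OC(C)(C)C)CC2)c2ccc(Br)cc2)cc1` gives > 20000 nM, which is a limit of the assay and not a number. Within the data shown here, compound 2 `COc1cc(N(Cc2ccc(Cl)cc2)C(=O)CSC(=S)N2CCN(C(=O)OC(C)(C)C)CC2)cc(OC)c1OC` gives 8490 nM, the only numeric value so far. Compound 3 `COc1ccc(CN(C(=O)CSC(=S)N2CCN(C(=O)OC(C)(C)C)CC2)c2cc(OC)c(OC)c(OC)c2)cc1F` carries 3-fluoro-4-methoxyphenyl in place of 4-chlorophenyl on a saturated chain carbon bound to an amide-type nitrogen. Among the measured compounds shown here, no measured step between two compounds is available, so the expectation stays loose. A modest gain in potency is expected, and the expected step is a 2.8-fold lower number from compound 2 to compound 3 (0.45 log units; beyond the scatter). The estimate for compound 3 is 3000 nM, with an expected range of 300 nM to 20000 nM.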

Compound 3, half-maximal inhibitory concentration: 8210 nM
Beside the measured number, compound 3's estimate is 2.7-fold (0.44 log units) below it; the range from low to high includes it.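

In this assay, replacing 4-chlorophenyl with 3-fluoro-4-methoxyphenyl on a saturated chain carbon bound to an amide-type nitrogen gives a 1.0-fold lower number from compound 2 to compound 3 (0.01 log units; within the scatter). Among these compounds, this is the first readable step at this position, and the two groups read alike despite the hydrogen-bond acceptor and the two extra heavy atoms that enter. Nothing at hand bears on why the two groups read alike.

As far as these compounds go, whether an amine or a carboxylic acid on this ring would separate from these values remains open. From the compounds shown here alone, a longer chain in place of the benzyl group is equally open.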